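Swapping the Aryl Ring on the Piperazine Amide

The compounds below may be only part of what the source reports. "The series", "measured", "known", "first", "only" and "open" are said of these compounds alone.

Measured so far:
- Compound 1 `O=C(COCc1ccccc1)N1CCN(c2ccccc2Cl)CC1`: 1100 nM
- Compound 2 `O=C(COCc1ccccc1)N1CCN(c2ccc(Cl)cc2)CC1`: 350 nM
- Compound 3 `O=C(COCc1ccccc1)N1CCN(c2ccc(F)cc2F)CC1`: 300 nM

All three compounds were tested in a functional assay on HEK293 cells for positive allosteric modulation of metabotropic glutamate receptor 5 (Homo sapiens), read by FLIPR and calcium flux; on this read-out higher numbers stand for an effect only at larger amounts of compound and lower numbers for an effect already at smaller amounts. Compound 1 gives the highest number of the three, so the effect appears only at the largest amount of compound. Moving to compound 2 lowers the number: a 3.1-fold lower number from compound 1 to compound 2 (0.50 log units; beyond the scatter). Moving to compound 3 does much the same: a 3.7-fold lower number from compound 1 to compound 3 (0.56 log units; beyond the scatter). Between compound 2 and compound 3 the difference is small: a 1.2-fold lower number from compound 2 to compound 3 (0.07 log units; within the scatter).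

Compound 4 `O=C(COCc1ccccc1)N1CCN(c2cc(Cl)ccn2)CC1` has not yet been measured. It differs from compound 1 in one place: 4-chloropyridin-2-yl in place of 2-chlorophenyl on an amine nitrogen in a ring. The two measured steps from compound 1 bear on this change, since each also replaces the 2-chlorophenyl group with another aromatic ring and each gives a modest lowering of the number. The new ring in compound 4 is of a kind not seen in the measured set, so a step of similar size downward is the expectation, with considerable uncertainty in both directions. The expected step is a 2.2-fold lower number from compound 1 to compound 4 (0.34 log units; beyond the scatter). Compound 4 is therefore estimated at 500 nM, with a likely range from 150 nM to 1800 nM.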

Compound 4, half-maximal effective concentration: 570 nM
Beside the measured number, compound 4's estimate is 1.1-fold (0.06 log units) below it; the range from low to high includes it.
By their numbers in this assay, from the lowest: compounds 3, 2, 4 and 1 (each within the scatter of the next, the first and the last beyond it).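

Within the data shown here, compound 4 is the first compound here whose ring on the amine nitrogen holds a hetero atom, which brings in one hydrogen-bond acceptor, yet a 1.9-fold lower number from compound 1 to compound 4 (0.29 log units; within the scatter) does not separate it from the 2-chlorophenyl compound. The other two comparisons read the same way, with a 1.9-fold higher number from compound 3 to compound 4 (0.28 log units; within the scatter) and a 1.6-fold higher number from compound 2 to compound 4 (0.21 log units; within the scatter), so at this position a 4-chloropyridin-2-yl ring cannot be told apart from any of the three carbon-only rings, even though compound 1 and compound 3 do differ beyond the scatter. Nothing at hand explains how the ring nitrogen or the chlorine contributes to this result.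

Going by these compounds, the step from the 2-chlorophenyl to the 4-chloropyridin-2-yl group changes the ring atoms and the place of the chlorine together, so the share of each stays open, and an unsubstituted pyridin-2-yl ring or a 2-chloropyridine isomer would be needed to pull them apart. On these data alone, whether a second ring nitrogen, as in a pyrimidine, or a different group on the pyridine ring, such as a nitrile or a methoxy group, would move the number beyond the scatter also remains open.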